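The source may report more compounds than this note shows. Statements on the series, on what has been measured and on what is new or still open speak of the compounds shown alone.

Compound 1 `COc1ccc(Oc2ccc([N+](=O)[O-])cc2-c2ccsc2S(=O)(=O)N2CCN(C(=S)Nc3ccc(Cl)cc3)CC2)cc1OC` and compound 2 `COc1ccc(Oc2ccc([N+](=O)[O-])cc2-c2ccsc2S(=O)(=O)N2CCN(C(=S)Nc3ccc([N+](=O)[O-])cc3)CC2)cc1OC` share one core and differ only on the aryl of the thiourea. In an assay for binding affinity to Apoptosis regulator Bcl-2 (Homo sapiens), read by fluorescence polarization, with stated times of 30 min and 20 min, tested at 100 uM (a lower number here means less inhibition, a higher number more inhibition at the concentration tested (going by the name of the read-out)), compound 1 gives 18%, and compound 2 gives 16%. Among the compounds with values here, the one measured step, a number 2 percentage points lower from compound 1 to compound 2 (within the scatter), shows that exchanging the group on the thiourea aryl leaves the read-out where it was. On the numbers shown, compound 1 stands with the higher of the two values, though its neighbour compound 2 sits within the scatter of it, so no order between them can be claimed.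

Compound 3 `COc1ccc(Oc2ccccc2-c2ccsc2S(=O)(=O)N2CCN(C(=S)Nc3ccc(Cl)cc3)CC2)cc1OC` is not yet measured. It keeps the thiourea aryl of compound 1 and changes the core instead: hydrogen in place of nitro on an aromatic carbon. Within the data shown here, no measured step touches this part of the molecule, so the step from compound 1 to compound 2 gives no direct guide; it only shows that a change at another place left the read-out unmoved. Among the measured compounds shown here, with no bearing step, the expectation for compound 3 is a value near that of compound 1, with a step that is estimated as a number 4 percentage points lower from compound 1 to compound 3 (within the scatter), which would lie within the scatter. Compound 3 is therefore estimated to give 14% in this assay, within a range from 2% to 28%.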

Compound 3, a percentage reported as inhibition, at one concentration (the size of the read-out at that concentration, not a potency): 18%
Beside the measured number, compound 3's estimate is 4 percentage points below it, and the stated range covers the measured number.
By their numbers in this assay, from the lowest: compounds 2, 1 and 3 (each within the scatter of the next).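

The step in the core now has a measured reading of its own: hydrogen in place of nitro on an aromatic carbon, meta to a large group and para to a 3,4-dimethoxyphenoxy group, gives no change at the digits printed from compound 1 to compound 3 (within the scatter) in this assay for this change. Within the data shown here, the earlier compounds had tested only the thiourea aryl, so this is the first sign that the read-out also holds when the nitro group, with its three heavy atoms and two hydrogen-bond acceptors, leaves the shared core, and compound 3 stands at 18% without it. This is a reading at one concentration and not a potency, and no supporting measurement is available to account for it.

The compounds shown leave open how an amine, a carboxylic acid or a methoxy group at this same place would read, since hydrogen is the only replacement for nitro on view. They also leave open whether hydrogen in place of nitro would read the same when the thiourea aryl carries the nitro group of compound 2 rather than the chloro group of compound 1.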